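Swapping furan for thiophene on a weakly active nucleoside

A few compounds are considered here, and "the series" means these few. Any claim that something is new, unique, unknown or untested is made for them only; others in the source may bear on it.

Compound 1 `CSc1ncnc2c1c(-c1ccccc1)cn2[C@@H]1O[C@H](CO)[C@@H](O)[C@H]1O` gives > 20000 nM as a limit of the assay
Compound 2 `Cc1ncnc2c1c(-c1cccs1)cn2[C@@H]1O[C@H](CO)[C@@H](O)[C@H]1O` gives > 20000 nM as a limit of the assay
Compound 3 `Nc1nc2c(c(-c3ccoc3)cn2[C@@H]2O[C@H](CO)[C@@H](O)[C@H]2O)c(=O)[nH]1` gives 17600 nM as a measured number

Among the compounds with values here, in a functional assay on HCT-116 cells (Homo sapiens), read by MTT assay, with a stated time of 72 h (on this read-out lower numbers stand for stronger inhibition and higher numbers for weaker inhibition), compound 3 gives 17600 nM and holds the only true number of the three. The other two values are described by the limit of > 20000 nM in this assay, at which 2 of the 3 values shown sit, and are limits, not numbers.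

Compound 4 `Nc1nc2c(c(-c3ccsc3)cn2[C@@H]2O[C@H](CO)[C@@H](O)[C@H]2O)c(=O)[nH]1` carries thiophen-3-yl in place of furan-3-yl on an aromatic carbon and otherwise matches compound 3. Within the data shown here, no measured pair shows such a swap, so the expectation rests on compound 3 at 17600 nM alone. No step beyond the scatter is expected, in either direction. The expected change is a 1.2-fold lower number from compound 3 to compound 4 (0.07 log units; within the scatter) and stays within that scatter. For compound 4 the estimated value is 15000 nM with an expected range from 5000 nM to 30000 nM in this assay.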

Compound 4, half-maximal inhibitory concentration: > 20000 nM
Compound 4 gave a limit, no number; the forecaster's own chance of this, stated with the estimate: 40%; middle value at least 1.3-fold (0.12 log units) away from the limit.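

In this assay compound 4 gives > 20000 nM, which is a limit and not a number. The step is an at least 1.1-fold higher number from compound 3 to compound 4 (0.05 log units; that floor lies within the scatter), so thiophen-3-yl in place of furan-3-yl brings no gain at this position, though only the smallest possible size of the change can be read. With this result, the one measured number stands almost alone, and a limit now describes most of the set: the limit of > 20000 nM in this assay, at which 3 of the 4 values shown sit.

On these data alone, how far compound 4 truly lies past its limit stays open. Also open, as far as these compounds go, is whether an amine or a longer chain in this place would give a clearly lower number.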